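The compounds below may be only part of what the source reports. "The series", "measured", "known", "first", "only" and "open" are said of these compounds alone.

Of the compounds shown here, three built on a shared core have been measured so far in a physicochemical assay for solubility, in phosphate buffer, with a stated time of 18 h (a higher number here means a more soluble compound, a lower number a less soluble compound), and they spread widely. Compound 1 `Cc1ncc2c(N)c(C#N)c(N)nc2n1` gives 783000 nM in this assay and compound 2 `CC(C)Cc1ncc2c(N)c(C#N)c(N)nc2n1` gives 268000 nM there. Compound 3 `CC(C)(C)c1nc(-c2ccccc2)c2c(N)c(C#N)c(N)nc2n1` gives 4000 nM and so holds the lowest number of the three, clearly apart from both others.

Compound 4 `CC(C)(C)c1nc(-c2ccn[nH]2)c2c(N)c(C#N)c(N)nc2n1` has not been measured yet. It differs from compound 3 in one place, with 1H-pyrazol-5-yl in place of phenyl on an aromatic carbon.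

Within the data shown here, only one measured step changes a single place, and it shows (a 2.9-fold lower number from compound 1 to compound 2 (0.47 log units; beyond the scatter)) when isopropyl replaces a hydrogen on a saturated chain carbon bound to an aromatic carbon. Among the measured compounds shown here, that step bears on the new change only indirectly, as no measured pair involves the phenyl. It does show that one local swap on this core can move the number modestly. There, a carbon-only group came in and the number fell, whereas here a carbon-only ring leaves and a ring with nitrogen enters. A modest rise is therefore expected, with real doubt about its direction. The estimated step is (a 3.0-fold higher number from compound 3 to compound 4 (0.48 log units; beyond the scatter)) in this assay. For compound 4 the estimated value is 12000 nM with an expected range from 3000 nM to 50000 nM in this assay.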

Compound 4, solubility: 13500 nM
Beside the measured number, compound 4's estimate is 1.1-fold (0.05 log units) below it, and the stated range covers the measured number.
By their numbers in this assay, from the lowest: compound 3; then compound 4; then compound 2; then compound 1.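

In this assay, the aromatic carbon that carries the phenyl group responds to a change of ring, and swapping phenyl for 1H-pyrazol-5-yl gives a 3.4-fold higher number from compound 3 to compound 4 (0.53 log units; beyond the scatter), the first step read at this position. Here a six-membered aromatic ring of carbon only leaves and a five-membered aromatic ring with 2 hetero atoms enters, bringing 1 hydrogen-bond donor and 1 hydrogen-bond acceptor, so the number moves up, whereas the only earlier step, a 2.9-fold lower number from compound 1 to compound 2 (0.47 log units; beyond the scatter), went down when isopropyl came in at a different place on the core. No measurement shown gives a reason for this rise, and this single pair cannot say which part of the change is responsible.

A pyridyl ring, which keeps six ring members while adding a ring nitrogen, or a phenyl group carrying an amine or a carboxylic acid, could help separate ring size from the presence of nitrogen or other added groups at this position. As far as these compounds go, it also stays open whether the same ring swap would give a step of similar size if a cyclopropyl ring stood in place of the tert-butyl group.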